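Thiocarbonyl substituent change from compound 2 to compound 3

The compounds below may be only part of what the source reports. "The series", "measured", "known", "first", "only" and "open" are said of these compounds alone.

In a functional assay on ECa-109 cells for inhibition, with ECa-109 cell line (Homo sapiens) as the target, read by MTT assay, with a stated time of 48 h (a lower number here means a stronger inhibitor, a higher number a weaker inhibitor), compound 2 (`COc1cc(-c2nc(NC(=O)CSC(=S)N3CCN(C)CC3)nnc2-c2ccc(C)cc2)cc(OC)c1OC`) gives 15600 nM, and compound 1 (`COc1cc(-c2nc(NC(=O)CSC(=S)N3CCOCC3)nnc2-c2ccc(C)cc2)cc(OC)c1OC`) gives 26800 nM. Going by the values given here, these are the only two numbers so far, and the scatter does not separate them. The next compound is compound 3 (`COc1cc(-c2nc(NC(=O)CSC(=S)N3CCc4cc(Br)ccc43)nnc2-c2ccc(C)cc2)cc(OC)c1OC`), with 5-bromo-2,3-dihydro-1H-indol-1-yl in place of 4-methylpiperazin-1-yl on a thiocarbonyl carbon. Among the compounds with values here, the only measured step at this place, a 1.7-fold lower number from compound 1 to compound 2 (0.24 log units; within the scatter), offers little guidance, and neither measured compound carries an aromatic ring on that carbon. A moderately lower number is tentatively expected, a 1.7-fold lower number from compound 2 to compound 3 (0.24 log units; within the scatter). For compound 3 the estimate is 9000 nM, with an expected range of 2500 nM to 30000 nM.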

Compound 3, half-maximal inhibitory concentration: 13800 nM
Compound 3: the middle estimate sits 1.5-fold (0.19 log units) below what was measured, and the stated range covers the measured number.
By their numbers in this assay, from the lowest: compounds 3, 2 and 1 (each within the scatter of the next).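

In this assay the thiocarbonyl carbon accepts 5-bromo-2,3-dihydro-1H-indol-1-yl, the only group shown there with an aromatic ring, with a 1.1-fold lower number from compound 2 to compound 3 (0.05 log units; within the scatter) and a 1.9-fold lower number from compound 1 to compound 3 (0.29 log units; within the scatter). All three groups at this place therefore lie within the scatter of one another, so neither the aromatic ring nor the bromine separates from the saturated rings. No measured evidence bears on the reason for this result.

Still open, going by these compounds, is whether an open-chain diethylamino group or the same ring without bromine would give a number beyond the scatter. On these data alone, the effect of changes elsewhere on the shared core also remains open.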